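The source may hold more compounds than are shown below. What is called first, only, known or untested is meant among the compounds shown, and "the series" means these compounds.

In a functional assay with Melanocortin receptor 4 (Homo sapiens) as the target, read by cAMP accumulation (a lower number here means that less compound is needed, a higher number that more compound is needed for the effect), compound 1 `COc1ccc(-n2nc(Sc3ccc(Cl)cc3)cc(CC[C@@H](C)NC(=O)[C@H]3CNCC[C@@H]3c3ccc(Cl)cc3)c2=O)cc1` gives 210 nM. Compound 2 `COc1ccc(-n2nc(Sc3ccc(Cl)cc3)cc(CC[C@@H](C)NC(=O)[C@H]3CNCC[C@@H]3c3ccc(C)cc3)c2=O)cc1` carries the change (methyl in place of chloro on an aromatic carbon), and in this assay compound 2 gives 1100 nM; that change made a 5.2-fold higher number from compound 1 to compound 2 (0.72 log units; beyond the scatter). Compound 3 `COc1ccc(-n2nc(Sc3ccc(Cl)cc3)cc(CC[C@@H](C)NC(=O)[C@H]3CNC[C@@H]3c3ccc(Cl)cc3)c2=O)cc1` has a core different from that of compound 1, and the difference between the two cores is not broken down here; in this assay compound 3 gives 230 nM, a number within the scatter of compound 1. Compound 4 `COc1ccc(-n2nc(Sc3ccc(Cl)cc3)cc(CC[C@@H](C)NC(=O)[C@H]3CNC[C@@H]3c3ccc(C)cc3)c2=O)cc1` is not yet measured; it differs from compound 3 by methyl in place of chloro on an aromatic carbon, the same change at the same place as between compound 1 and compound 2. Because the earlier change made a 5.2-fold higher number from compound 1 to compound 2 (0.72 log units; beyond the scatter), the expected step for compound 4 is a 4.8-fold higher number from compound 3 to compound 4 (0.68 log units; beyond the scatter). In this assay compound 4 is estimated at 1100 nM, expected between 400 nM and 3000 nM.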

Compound 4, half-maximal effective concentration: 750 nM
The estimate for compound 4 lay 1.5-fold (0.17 log units) above the measured number, and the stated range covers the measured number.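

In this assay, methyl in place of chloro on an aromatic carbon again gave a higher number, the new step being a 3.3-fold higher number from compound 3 to compound 4 (0.51 log units; beyond the scatter). Set beside the earlier step, the change carried from the core of compound 1 to the core of compound 3 in the same direction, and the two sizes do not differ beyond the scatter: the same change on two cores in this assay, a 5.2-fold higher number (0.72 log units; beyond the scatter) from compound 1 to compound 2 and a 3.3-fold higher number (0.51 log units; beyond the scatter) from compound 3 to compound 4, 1.6-fold (0.21 log units) apart, within the scatter of two such steps. Within the data shown here, this rests on only two pairs and one change, so it shows no general rule for this series and does not explain why the number rises.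

The compounds shown leave open whether other groups at the same place, such as fluoro, methoxy or trifluoromethyl, would behave like methyl. They also leave open whether the step would hold on a third core.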